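Iodo to methyl step carried over to compound 4

A few compounds are considered here, and "the series" means these few. Any claim that something is new, unique, unknown or untested is made for them only; others in the source may bear on it.

All numbers below come from a functional assay on HeLa cells (Homo sapiens) for antiproliferative activity, with a stated time of 48 h; a lower number here means a stronger inhibitor, a higher number a weaker inhibitor.

Compound 1 `C=C(Br)C(=O)Nc1ccc(/C=C/C(=O)c2ccc(I)cc2)cc1`: in this assay compound 1 gives 7700 nM
Compound 2 `C=C(Br)C(=O)Nc1ccc(/C=C/C(=O)c2ccc(C)cc2)cc1`: in this assay compound 2 gives 2100 nM
Compound 3 `Nc1ccc(/C=C/C(=O)c2ccc(I)cc2)cc1`: in this assay compound 3 gives 58000 nM

Compound 1 and compound 2 differ in one place, (methyl in place of iodo on an aromatic carbon), and the step is a 3.7-fold lower number from compound 1 to compound 2 (0.56 log units; beyond the scatter). Compound 1 and compound 3 differ by hydrogen in place of (1-bromoethenyl)carbonyl on a nitrogen on an aromatic ring, with the step of a 7.5-fold higher number from compound 1 to compound 3 (0.88 log units; beyond the scatter). Compound 3 thus carries the highest number of the three, and its gap to compound 2 is larger still, both gaps lying beyond the scatter. For the measured compounds named here, no step between compound 2 and compound 3 is computed here; their two values simply show compound 3 well above compound 2.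

Compound 4 `Cc1ccc(C(=O)/C=C/c2ccc(N)cc2)cc1` is not yet measured. Its difference from compound 3 is methyl in place of iodo on an aromatic carbon. This is the same change as that from compound 1 to compound 2; the place is described in the same words for both pairs, and the change occurs twice in all among the compounds shown. The two cores differ by hydrogen in place of (1-bromoethenyl)carbonyl on a nitrogen on an aromatic ring as told above.

Going by the values given here, the step from compound 3 to compound 4 is expected to be a 3.4-fold lower number from compound 3 to compound 4 (0.53 log units; beyond the scatter), resting on the single earlier instance, a 3.7-fold lower number from compound 1 to compound 2 (0.56 log units; beyond the scatter); with only one pair to lean on, the range is kept wide. For compound 4 the expected value in this assay is 17000 nM, estimated to lie between 7000 nM and 45000 nM.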

Compound 4, half-maximal inhibitory concentration: 40000 nM
Beside the measured number, compound 4's estimate is 2.4-fold (0.37 log units) below it; low and high end bracket the measured number.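

In this assay, methyl in place of iodo gives a 1.5-fold lower number from compound 3 to compound 4 (0.16 log units; within the scatter), and this step agrees with the earlier one on the core of compound 1: the same change on two cores in this assay, a 3.7-fold lower number (0.56 log units; beyond the scatter) from compound 1 to compound 2 and a 1.5-fold lower number (0.16 log units; within the scatter) from compound 3 to compound 4, 2.5-fold (0.40 log units) apart, within the scatter of two such steps. Hydrogen in place of (1-bromoethenyl)carbonyl on the nitrogen gives a 19-fold higher number from compound 2 to compound 4 (1.28 log units; beyond the scatter), and this too agrees with the earlier step on the other core: the same change on two cores in this assay, a 7.5-fold higher number (0.88 log units; beyond the scatter) from compound 1 to compound 3 and a 19-fold higher number (1.28 log units; beyond the scatter) from compound 2 to compound 4, 2.5-fold (0.40 log units) apart, within the scatter of two such steps. Both changes therefore carry from one core to the other without a difference that can be told from the scatter, but two pairs per change do not show that the steps are equal, and the methyl-for-iodo step lies beyond the scatter on one core and within it on the other, so a real gain on the core of compound 3 is not established.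

The compounds shown leave open how a chloro, methoxy or trifluoromethyl group would behave on the same aromatic carbon, and whether an acetyl group or a propenoyl group without bromine on the nitrogen would give a step of similar size. They also leave open whether either step holds on cores other than these two.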